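Ester chain lengthening in a small dihydropyrimidinone series

The compounds below may be only part of what the source reports. "The series", "measured", "known", "first", "only" and "open" are said of these compounds alone.

Two compounds from the series have a number in an assay on membranes from CHO cells for displacement of a labelled ligand from adenosine receptor A1 (Homo sapiens), read by scintillation counting, with a stated time of 60 min, tested at 1 uM (a lower number here means less inhibition, a higher number more inhibition at the concentration tested (going by the name of the read-out)), so far. Compound 1 `CC1=C(C(=O)OCC(C)C)C(c2ccoc2)NC(=O)N1C` gives 4% there, and compound 2 `CCOC(=O)C1=C(C)N(C)C(=O)NC1c1ccsc1` gives 32%. Compound 2 thus stands highest of the two, with compound 1 a step below it that lies beyond the usual scatter. The two differ from each other in more than one place, so no single change can be read from that gap.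

Compound 3 `CC1=C(C(=O)OCC(C)C)C(c2ccsc2)NC(=O)N1C` is the next member to be measured in this assay. It differs from compound 2 by isopropyl in place of methyl on a saturated chain carbon bound to an oxygen next to a carbonyl group. Within the data shown here, no measured pair isolates this change, so the direction of the step is open; on the two numbers available, a move downward from compound 2 toward compound 1 seems at least as likely as none, and the step from compound 2 to compound 3 is expected to be a number 14 percentage points lower from compound 2 to compound 3 (beyond the scatter). Compound 3 is estimated at 18%, within a range from 0% to 40%.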

Compound 3, a percentage reported as inhibition, at one concentration (the size of the read-out at that concentration, not a potency): 8%
Beside the measured number, compound 3's estimate is 10 percentage points above it; measured number inside the range.
By their numbers in this assay, from the lowest: compounds 1 and 3 (each within the scatter of the next); then compound 2.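

In this assay, the change of isopropyl in place of methyl on a saturated chain carbon bound to an oxygen next to a carbonyl group, read further out as ethoxycarbonyl to isobutoxycarbonyl, now stands alone with thiophen-3-yl held fixed, and it gives a number 24 percentage points lower from compound 2 to compound 3 (beyond the scatter). With isobutoxycarbonyl held fixed, thiophen-3-yl in place of furan-3-yl on a saturated ring carbon gives a number 4 percentage points higher from compound 1 to compound 3 (within the scatter), so these two rings are not told apart with this ester. The compounds shown offer no measured reason for the ester step.

As far as these compounds go, whether the ester step carries over to the furan-3-yl compounds remains open. So does the reading in this assay of a methoxycarbonyl group, a benzyl ester or a carboxylic acid in this place.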